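From trifluoromethyl to difluoromethyl on compound 2

The compounds below may be only part of what the source reports. "The series", "measured", "known", "first", "only" and "open" are said of these compounds alone.

Values measured in an ADME assay on a cell-free system (plasma, Mus musculus) for protein binding, read by LC-MS, using equilibrium dialysis, with a stated time of 4.5 h, tested at 5 uM; on this read-out higher numbers stand for a larger free fraction and lower numbers for a smaller free fraction:
Compound 1 `C[C@]1(c2cc(NC(=O)c3ccc(C#N)cn3)ccc2F)N=C(N)CO[C@H]1C(F)(F)F` gives 0.23
Compound 2 `COc1cnc(C(=O)Nc2ccc(F)c([C@@]3(C)N=C(N)CO[C@H]3C(F)(F)F)c2)cn1` gives 0.155
Compound 3 `COc1cnc(C(=O)Nc2ccc(F)c([C@@]3(C)N=C(N)COC3=C(F)F)c2)cn1` gives 0.146

Compound 2 cannot be separated from compound 1 or compound 3 on these numbers, since all three lie within the usual scatter of one another. The change now in question leads to compound 4 `COc1cnc(C(=O)Nc2ccc(F)c([C@@]3(C)N=C(N)CO[C@H]3C(F)F)c2)cn1`, which has hydrogen in place of fluoro on a saturated chain carbon bound to two fluorine atoms and a saturated ring carbon. The same difference can be read as trifluoromethyl to difluoromethyl.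

For the measured compounds named here, only one measured step changes a single place, and it lies elsewhere in the structure. This is a 1.5-fold lower number from compound 1 to compound 2 (0.17 log units; within the scatter), with 5-methoxypyrazin-2-yl in place of 5-cyanopyridin-2-yl on a carbonyl carbon. Going by the values given here, no measured step touches the trifluoromethyl group, so the data give neither a direct size nor a direction for this change. With so little spread among the measured compounds, no step beyond the scatter is expected in this assay. The expected change is a 1.1-fold higher number from compound 2 to compound 4 (0.04 log units; within the scatter) and it stays within the scatter. Compound 4 is therefore estimated at 0.17, with an expected range from 0.11 to 0.26.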

Compound 4, unbound fraction in the Mus musculus assay: 0.279
Compound 4: the middle estimate sits 1.6-fold (0.22 log units) below what was measured; measured number outside the range, above it.
By their numbers in the Mus musculus assay, from the lowest: compounds 3, 2, 1 and 4 (each within the scatter of the next).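

For the compounds shown here, in the Mus musculus assay, the step of a 1.8-fold higher number from compound 2 to compound 4 (0.26 log units; within the scatter) gives this change at this position its first direct reading, which the earlier compounds could not supply, and on this read-out it does not separate the two compounds. The same exchange of fluoro for hydrogen is nevertheless not silent, since in a physicochemical assay for acid dissociation, using potentiometric titration, at 25 degrees C, it gives a number 0.60 log units higher from compound 2 to compound 4 (beyond the scatter), a step that is beyond the scatter. In the physicochemical assay compound 2 gives 7.8 and compound 4 gives 8.4. Removing one fluoro from the trifluoromethyl group therefore alters the measured acid dissociation constant even though the unbound fraction stays within the scatter: the measured acid dissociation constant of compound 2, 7.8, and of compound 4, 8.4, a number 0.60 log units higher (beyond the scatter)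

A single pair cannot show whether the shift in acid dissociation constant has any bearing on the unbound fraction, nor whether the same exchange would read alike with the 5-cyanopyridin-2-yl amide of compound 1. Going by these compounds, whether the two read-outs move together at this position also stays open, and a fluoromethyl or a plain methyl group on the same saturated ring carbon would extend the series far enough to test it.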